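This account rests on a few compounds, and the source may have more. Where it says the series, first, only, none or still open, it means among the compounds named here.

Compound 2 `COc1ccc(-c2cc(C(=O)NC3CCCCCC3)c(OCc3ccc(F)cc3)nc2C)cc1` belongs to a small set of cycloheptyl amides examined in an assay on HEK293 cells for inhibition of Lysophosphatidylserine lipase ABHD12 (Homo sapiens), read by scintillation counting, with stated times of 30 min and 5 min; a lower number here means a stronger inhibitor, a higher number a weaker inhibitor. In this assay compound 2 gives > 10000 nM, which is a limit of the assay and not a number. Compound 1 `Cc1c(-c2ccc(F)cc2)cc(C(=O)NC2CCCCCC2)c(=O)n1Cc1ccc(F)cc1` gives 600 nM in this assay. Compound 3 `Cc1c(Cl)cc(C(=O)NC2CCCCCC2)c(=O)n1Cc1ccc(F)cc1` gives > 10000 nM, again a limit. Compound 2 thus sits at the limit of > 10000 nM in this assay, at which 2 of the 3 values shown sit. Compound 4 `Cc1ccc(C(=O)NC2CCCCCC2)c(OCc2ccc(F)cc2)n1` differs from compound 2 by hydrogen in place of 4-methoxyphenyl on an aromatic carbon. For the measured compounds named here, the only comparable measured step is an at least 16-fold higher number from compound 1 to compound 3 (1.22 log units; beyond the scatter), where a 4-fluorophenyl on an aromatic carbon was also removed. Since compound 2 already sits at the limit, a further weakening cannot be resolved. Compound 4 is therefore expected to stay at the limit, estimated at 30000 nM within 10000 nM to 100000 nM. The step this implies is expected to be a step that the limit leaves unreadable from compound 2 to compound 4.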

Compound 4, half-maximal inhibitory concentration: > 10000 nM
Compound 4: only a limit was reported (the forecaster's own chance of this, stated with the estimate: 90%); the middle value is on the limit's open side.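

No new step can be read between compound 2 and compound 4, as each gives only a limit and not a number in this assay: the limit of > 10000 nM in this assay, at which 3 of the 4 values shown sit. The compounds shown leave open whether hydrogen in place of 4-methoxyphenyl changes inhibition at all.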